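The source may hold more compounds than are shown below. What is called first, only, known or untested is meant among the compounds shown, and "the series" means these compounds.

Measured in a functional assay on HCT-116 cells (Homo sapiens), read by MTT assay, with a stated time of 72 h; a higher number here means a weaker inhibitor, a lower number a stronger inhibitor:
- compound 1 `Cc1nc(N)c2c(-c3ccco3)cn([C@@H]3O[C@H](CO)[C@@H](O)[C@H]3O)c2n1` gives > 20000 nM, a limit
- compound 2 `Cc1nc(N)c2c(-c3cc4ccccc4o3)cn([C@@H]3O[C@H](CO)[C@@H](O)[C@H]3O)c2n1` gives > 20000 nM, a limit

Compound 2 has no number on this scale, only the limit > 20000 nM. Going by the values given here, the same holds across the series so far, with the limit of > 20000 nM in this assay, at which 2 of the 2 values shown sit. The change that leads to compound 3 `Cc1nc(N)c2c(I)cn([C@@H]3O[C@H](CO)[C@@H](O)[C@H]3O)c2n1` is iodo in place of 1-benzofuran-2-yl on an aromatic carbon, and it falls on an aromatic carbon of a five-membered aromatic ring with 1 nitrogen. Among the compounds with values here, only one measured step bears on this place, namely a step that the two limits leave unreadable from compound 1 to compound 2, and it has no size that can be read. With no measured size to carry over, only a weak expectation is possible: compound 3 will probably stay near the limit, with some chance of a stronger inhibitor. The estimated change is an at least 1.3-fold lower number from compound 2 to compound 3 (0.12 log units; that floor lies within the scatter), which is expected to be small. For compound 3 the expected value in this assay is 15000 nM, with an estimated range from 2000 nM to 40000 nM.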

Compound 3, half-maximal inhibitory concentration: > 20000 nM
Compound 3 ended at the assay's limit (the forecaster's own chance of this, stated with the estimate: 60%); middle value at least 1.3-fold (0.12 log units) from the limit.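

In this assay compound 3 gives > 20000 nM, a limit. The steps among compound 1, compound 2 and compound 3 therefore cannot be read: the limit of > 20000 nM in this assay, at which 3 of the 3 values shown sit.

The compounds shown leave open how furan-2-yl, 1-benzofuran-2-yl and iodo compare on this aromatic carbon, and whether any group there gives a readable number in this assay.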